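The source may report more compounds than this note shows. Statements on the series, on what has been measured and on what is new or still open speak of the compounds shown alone.

Compound 1 `COc1cccc(N2CCN(C(=O)C(C)N3C(=O)CCC3=O)CC2)c1` stands level with its two neighbours in a functional assay on the whole organism (strain Swiss) with Mus musculus as the target, in the maximal electroshock model, with a stated time of 0.5 h, at a dose of 100 mg/kg by the intraperitoneal route (on this read-out higher numbers stand for a stronger effect at the one dose given and lower numbers for a weaker effect), where compound 1 gives 0%. Compound 2 `CC(C(=O)N1CCN(c2ccccc2)CC1)N1C(=O)CCC1=O` gives 0% and compound 3 `CC(C(=O)N1CCN(c2ccccc2F)CC1)N1C(=O)CCC1=O` gives 0%, so no change at the digits printed from compound 1 to compound 2 (within the scatter), no change at the digits printed from compound 1 to compound 3 (within the scatter) and no change at the digits printed from compound 2 to compound 3 (within the scatter) all lie within the scatter. Compound 4 `Cc1cccc(N2CCN(C(=O)C(C)N3C(=O)CCC3=O)CC2)c1` differs from compound 1 by methyl in place of methoxy on an aromatic carbon. Among the measured compounds shown here, the one measured step that removes the methoxy group, no change at the digits printed from compound 1 to compound 2 (within the scatter), bears most directly on this change, and the substitutions on an aromatic carbon in the other steps were likewise without effect beyond the scatter. A step of no size beyond the scatter is therefore expected, no change at the digits printed from compound 1 to compound 4 (within the scatter). Compound 4 is estimated to give 0%, between 0% and 10%.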

Compound 4, a percentage reported as activity, at one dose (the size of the read-out at that dose, not a potency): 0%
Compound 4: middle estimate and measured number agree at the digits printed; the measured number falls inside the stated range.
By their numbers in this assay, from the lowest: compounds 1, 2, 3 and 4 (each within the scatter of the next).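

In this assay, methyl in place of methoxy on the aromatic carbon meta to a large group adds a carbon-only substituent to the set, and the step reads (no change at the digits printed from compound 1 to compound 4 (within the scatter)). Against the two other compounds, the readings are (no change at the digits printed from compound 3 to compound 4 (within the scatter)) and (no change at the digits printed from compound 2 to compound 4 (within the scatter)), so neither methyl, methoxy nor hydrogen at this place separates these compounds. No evidence at hand accounts for this outcome.

As far as these compounds go, whether trifluoromethyl or an amine at this place would raise the read-out remains open. So does whether these compounds would differ at another dose or time.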